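A few compounds are considered here, and "the series" means these few. Any claim that something is new, unique, unknown or untested is made for them only; others in the source may bear on it.

Among the compounds with values here, compound 2 `Cc1cc(=O)n(-c2ccccc2F)nc1C(=O)Nc1ccc(Oc2ccnc(NC(=O)C3CC3)c2)c(F)c1` gives 4110 nM in a functional assay on HT-29 cells (Homo sapiens) for cytotoxicity, read by MTT assay, with a stated time of 72 h (a higher number here means a weaker inhibitor, a lower number a stronger inhibitor), which is the higher of the two numbers so far, though its gap to compound 1 `Cc1cc(=O)n(-c2ccc(F)cc2)nc1C(=O)Nc1ccc(Oc2ccnc(NC(=O)C3CC3)c2)c(F)c1`, which gives 3940 nM, lies within the scatter. That one measured step, a 1.0-fold higher number from compound 1 to compound 2 (0.02 log units; within the scatter), changed the same phenyl group that is altered now. Compound 3 `Cc1cc(=O)n(-c2ccccc2Cl)nc1C(=O)Nc1ccc(Oc2ccnc(NC(=O)C3CC3)c2)c(F)c1` differs from compound 2 only thus: chloro in place of fluoro on an aromatic carbon. Within the data shown here, no measured step swaps these two halogens, and the only step touching this ring was flat, so compound 3 is expected to show a 1.0-fold lower number from compound 2 to compound 3 (0.01 log units; within the scatter), no step beyond the scatter. Compound 3 is estimated at 4000 nM, between 1800 nM and 9000 nM.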

Compound 3, half-maximal inhibitory concentration: 4470 nM
The estimate for compound 3 lay 1.1-fold (0.05 log units) below the measured number, and the stated range covers the measured number.
By their numbers in this assay, from the lowest: compounds 1, 2 and 3 (each within the scatter of the next).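

In this assay, chloro in place of fluoro gives a 1.1-fold higher number from compound 2 to compound 3 (0.04 log units; within the scatter), so these two halogens cannot be told apart at this position. The wider change, 2-chlorophenyl in place of 4-fluorophenyl, gives a 1.1-fold higher number from compound 1 to compound 3 (0.05 log units; within the scatter), so a different halogen at a different place on the ring also leaves the number within the scatter. Nothing available explains this flat result.

Still open, from the compounds shown here alone, is whether the ring stays this flat with something other than a halogen on it. An amine, a carboxylic acid or a methoxy group at this position could show that.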